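Linker exchange on the side chain of compound 2

The compounds below may be only part of what the source reports. "The series", "measured", "known", "first", "only" and "open" are said of these compounds alone.

Going by the values given here, compound 2 `CN(C)CCCSc1nc(-c2ccccc2)nc2ccccc12` stands at 6100 nM in an assay on cell membranes for displacement of a labelled ligand from sodium-dependent dopamine transporter (Rattus norvegicus) (a lower number here means a stronger inhibitor, a higher number a weaker inhibitor), the lower of only two numbers and within the scatter of compound 1 `CN(C)CCCOc1nc(-c2ccccc2)nc2ccccc12`, which gives 9900 nM in this assay. The step of a 1.6-fold lower number from compound 1 to compound 2 (0.21 log units; within the scatter) is the only measured one, also a linker exchange. Compound 3 `CN(C)CCCNc1nc(-c2ccccc2)nc2ccccc12` carries (3-(dimethylamino)propyl)amino in place of (3-(dimethylamino)propyl)sulfanyl on an aromatic carbon. Since that sole comparable step stayed within the scatter, no change beyond the scatter is expected for compound 3 in this assay. The expected step is a 1.0-fold lower number from compound 2 to compound 3 (0.01 log units; within the scatter). Compound 3 is therefore estimated at 6000 nM, with a range from 2000 nM to 18000 nM.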

Compound 3, inhibition constant: > 10000 nM
Compound 3: no number, only a limit (the forecaster's own chance of this, stated with the estimate: 5%); at least 1.6-fold (0.22 log units) between middle value and limit.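

In this assay compound 3 reaches only a limit of the assay, not a number: the limit of > 10000 nM in this assay, at which 1 of the 3 values shown sits.

Placing (3-(dimethylamino)propyl)amino on this aromatic carbon gives an at least 1.6-fold higher number from compound 2 to compound 3 (0.21 log units; that floor lies within the scatter), so the linker with a hydrogen-bond donor shows no gain over the sulfanyl linker, though the true size of the step stays unknown. Placing (3-(dimethylamino)propyl)amino in place of 3-(dimethylamino)propoxy gives a number no lower from compound 1 to compound 3 (the limit leaves the size open) and the size of that step cannot be read.

From the compounds shown here alone, the true value of compound 3 remains open. Also open, going by these compounds, is whether a longer chain or a piperidine in place of the dimethylamino group would move the number beyond the scatter.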